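The compounds below may be only part of what the source reports. "The series", "measured", "known", "first", "only" and "open" are said of these compounds alone.

Measured so far:
- compound 1, `COc1ccc(-c2cc(/C=C/C(=O)c3ccc(N)cc3)[nH]n2)cc1`: 100%
- compound 2, `COc1cc(-c2cc(/C=C/C(=O)c3ccc(Cl)c(Cl)c3)[nH]n2)cc(OC)c1OC`: 97%

In a functional assay on OVCAR-8 cells (Homo sapiens) for cytotoxicity, read by sulforhodamine B assay, with a stated time of 48 h, tested at 0.1 uM (a lower number here means a stronger effect, a higher number a weaker effect of the compound at the concentration tested), compound 1 gives 100% and compound 2 gives 97%. The two numbers sit within the usual scatter of each other, so nothing separates compound 2 from compound 1 on this read-out; both report essentially the full activity signal at the concentration tested, that is, little effect of either compound. Going by the values given here, no pair of measured compounds differs in one place only, so no single-change step is known.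

Compound 3, `COc1cc(-c2cc(/C=C/C(=O)c3ccc(F)c(F)c3)[nH]n2)cc(OC)c1OC`, is the next compound to be measured. It differs from compound 2 in one place: 3,4-difluorophenyl in place of 3,4-dichlorophenyl on a carbonyl carbon.

Among the compounds with values here, with no measured step to lean on, and with both measured compounds at the top of the read-out, no step beyond the scatter is expected in this assay for no change at the digits printed from compound 2 to compound 3 (within the scatter). Compound 3 is therefore expected to give 97%, in the range 85% to 105%.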

Compound 3, a percentage reported as activity, at one concentration (the size of the read-out at that concentration, not a potency): 96%
For compound 3 the middle estimate is 1 percentage points above the measured one, and the stated range covers the measured number.
By their numbers in this assay, from the lowest: compounds 3, 2 and 1 (each within the scatter of the next).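

Going by these compounds alone, this is the only single-change step so far: in this assay the read-out is a number 1 percentage points lower from compound 2 to compound 3 (within the scatter) with 3,4-difluorophenyl in place of 3,4-dichlorophenyl on a carbonyl carbon. At this position, the exchange of two chlorine atoms for two fluorine atoms therefore leaves no difference that can be read at the concentration tested, and both compounds stay near the top of the read-out, where little effect is seen. No available measurement bears on this result.

From the compounds shown here alone, it remains open whether a group of another kind on the carbonyl carbon, such as a naphthyl, a pyridyl or a phenyl carrying a carboxylic acid, would give a read-out apart from compound 3. Going by these compounds, whether compound 2 and compound 3 would separate at a higher concentration also remains open.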